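The source may report more compounds than this note shows. Statements on the series, on what has been measured and on what is new or still open speak of the compounds shown alone.

Working notes on the series. Compound 1 `C[S+]([O-])/C=C/c1cc(=O)c2cc(C#N)ccc2o1` carries a cyano group on the shared core. In a functional assay on A549 cells (Homo sapiens) for cytotoxicity, with a stated time of 48 h (a lower number here means a stronger inhibitor, a higher number a weaker inhibitor), compound 1 gives > 10000 nM, which is a limit of the assay rather than a number (the limit of > 10000 nM in this assay, at which 1 of the 3 values shown sits). Compound 2 `CCC(=O)Oc1ccc2oc(/C=C/[S+](C)[O-])cc(=O)c2c1` gives 2400 nM, and compound 3 `CC(C)COc1ccc2oc(/C=C/[S+](C)[O-])cc(=O)c2c1` gives 1100 nM, the lowest of the two numbers shown; the gap between them is a 2.2-fold lower number from compound 2 to compound 3 (0.34 log units; beyond the scatter). Compound 4 `CCCC(=O)Oc1ccc2oc(/C=C/[S+](C)[O-])cc(=O)c2c1` is not yet measured; its change from compound 3 is propylcarbonyl in place of isobutyl on an oxygen on an aromatic ring, so compound 4 carries an ester of the kind seen in compound 2, but longer. The step that bears on it is a 2.2-fold lower number from compound 2 to compound 3 (0.34 log units; beyond the scatter), ester to ether, run the other way; the steps of an at least 4.1-fold lower number from compound 1 to compound 2 (0.61 log units; beyond the scatter) and an at least 9.0-fold lower number from compound 1 to compound 3 (0.95 log units; beyond the scatter) start from a limit and set only a floor. A modest rise is therefore expected for compound 4, a 2.0-fold higher number from compound 3 to compound 4 (0.30 log units; within the scatter). Compound 4 is expected at 2200 nM, between 900 nM and 5500 nM.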

Compound 4, half-maximal inhibitory concentration: 2200 nM
Compound 4: middle estimate and measured number agree at the digits printed, and the stated range covers the measured number.
By their numbers in this assay, from the lowest: compounds 3, 4 and 2 (each within the scatter of the next, the first and the last beyond it). At a limit, above all of these: compound 1.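

With methyl added to the saturated chain of the ester, the two esters stay level (a 1.1-fold lower number from compound 2 to compound 4 (0.04 log units; within the scatter)), so this extension leaves the number unmoved. The change from isobutyl to propylcarbonyl on the oxygen gives a step within the scatter (a 2.0-fold higher number from compound 3 to compound 4 (0.30 log units; within the scatter)), so the ether's edge over the esters holds firmly against compound 2 only. Compound 1 is a limit of the assay, so its step sets only a floor (an at least 4.5-fold lower number from compound 1 to compound 4 (0.65 log units; beyond the scatter)): (the limit of > 10000 nM in this assay, at which 1 of the 4 values shown sits).

Going by these compounds, whether a much longer ester chain, or an amine or a carboxylic acid at the end of the chain on this oxygen, would move the number stays open.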